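From Thiomorpholine to Morpholine: A Small Expected Step

This account rests on a few compounds, and the source may have more. Where it says the series, first, only, none or still open, it means among the compounds named here.

Compound 2 `N/C(=N\NC(=S)N1CCSCC1)c1ccc(F)cn1` gives 84.6% in a functional assay on A-431 cells (Homo sapiens) for cytotoxicity, read by MTT assay, with a stated time of 72 h, tested at 30 uM; a higher number here means more inhibition of growth at the concentration tested, a lower number less inhibition of growth. Among the measured compounds shown here, that is the higher of the two numbers measured so far, but its only neighbour, compound 1 `N/C(=N\NC(=S)N1CCOCC1)c1ccccn1`, gives 78.8% in this assay, and that gap lies within the scatter, so the two cannot be told apart. Compound 3 `N/C(=N\NC(=S)N1CCOCC1)c1ccc(F)cn1` has not yet been measured. It differs from compound 2 in one place: morpholin-4-yl in place of thiomorpholin-4-yl on a thiocarbonyl carbon. For the measured compounds named here, no measured pair in this set differs only at that ring, so there is no step to lean on. Compound 1 already carries the morpholin-4-yl group and, because it gives 78.8%, sits close to compound 2. The step from compound 2 to compound 3 is therefore expected to be a number 3.6 percentage points lower from compound 2 to compound 3 (within the scatter), nothing beyond the scatter. Compound 3 is expected to give 81% in this assay, with a likely range from 66% to 92%.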

Compound 3, percent growth inhibition at one concentration: 82.3%
Beside the measured number, compound 3's estimate is 1.3 percentage points below it; the range from low to high includes it.
By their numbers in this assay, from the lowest: compounds 1, 3 and 2 (each within the scatter of the next).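

Among the compounds shown here, compound 3 gives the first direct reading of this ring swap on a thiocarbonyl carbon: with the rest of the structure unchanged, morpholin-4-yl in place of thiomorpholin-4-yl gives a number 2.3 percentage points lower from compound 2 to compound 3 (within the scatter) in this assay, so the two rings cannot be told apart here. For the compounds shown here, it also gives the first direct reading of fluoro in place of hydrogen on an aromatic carbon, a number 3.5 percentage points higher from compound 1 to compound 3 (within the scatter), so that change cannot be told from no change in this set. No measurement that could explain either small step is available.

The compounds shown leave open whether a piperidine ring or an open-chain diethylamino group on the thiocarbonyl carbon would move the number beyond the scatter. They also leave open whether chloro or methoxy in place of fluoro on the aromatic carbon would do so.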